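This account rests on a few compounds, and the source may have more. Where it says the series, first, only, none or still open, it means among the compounds named here.

Measured compounds in this series:

Compound 1 `Oc1cc2c(cc1CNc1ccccc1)OCCC2`: 1700 nM
Compound 2 `CC(=O)c1ccc(NCc2cc3c(cc2O)CCCO3)cc1`: 4100 nM
Compound 3 `Oc1cc2c(cc1CNc1ccccc1)OCC2`: 490 nM

All three were run in a functional assay for inhibition, with Homo sapiens as the target; on this read-out higher numbers stand for weaker inhibition and lower numbers for stronger inhibition. Compound 3 gives the lowest number of the set in this assay, with 490 nM, and its nearest neighbour is compound 1 with 1700 nM; compound 2 lies furthest from it with 4100 nM. The difference between the core of compound 1 and the core of compound 3 is not broken down here.

Within the core of compound 1, one change has been measured: acetyl in place of hydrogen on an aromatic carbon. This gave a 2.4-fold higher number from compound 1 to compound 2 (0.38 log units; beyond the scatter), a modest weakening that lies beyond the scatter.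

The same change is now to be applied to the core of compound 3, giving compound 4 `CC(=O)c1ccc(NCc2cc3c(cc2O)CCO3)cc1`, which is not yet measured in this assay. Its difference from compound 3 is acetyl in place of hydrogen on an aromatic carbon, with the place described in the same words as for the step from compound 1 to compound 2.

Given that this acetyl change was seen once, on the core of compound 1, and gave a 2.4-fold higher number from compound 1 to compound 2 (0.38 log units; beyond the scatter), a step of similar size is expected here, so that compound 4 is expected to sit at a 2.4-fold higher number from compound 3 to compound 4 (0.39 log units; beyond the scatter) relative to compound 3. Because compound 3 starts from 490 nM, compound 4 is estimated at 1200 nM in this assay, with a likely range from 600 nM to 2500 nM; this rests on a single earlier instance of the change, so the range is kept wide.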

Compound 4, half-maximal inhibitory concentration: 1200 nM
Estimate against measurement, compound 4: no gap at the digits printed; measured number inside the range.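

Acetyl in place of hydrogen on an aromatic carbon, para to a large group, also weakens inhibition on the core of compound 3 in this assay, with a 2.4-fold higher number from compound 3 to compound 4 (0.39 log units; beyond the scatter) as a modest step beyond the scatter. This is two instances on two cores, in one assay and with one group at one place, so it supports additive behaviour of the change across these two cores only and gives no rule for the series as a whole; it also says nothing about why the number rises. Set beside the earlier step, the size of the change carries over from the core of compound 1 to the core of compound 3 without a detectable difference: the same change on two cores in this assay, a 2.4-fold higher number (0.38 log units; beyond the scatter) from compound 1 to compound 2 and a 2.4-fold higher number (0.39 log units; beyond the scatter) from compound 3 to compound 4, 1.0-fold (0.01 log units) apart, within the scatter of two such steps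

Still open, going by these compounds, is whether a carboxylic acid, an amine or a longer chain in place of the acetyl would shift the number in the same direction and by a similar amount on both cores. Also open, on these data alone, is whether the step would keep its size on a core other than these two, or with the hydroxyl on the shared core replaced by a methoxy group.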